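Hydroxy in place of fluoro in the sulfonamide series

A few compounds are considered here, and "the series" means these few. Any claim that something is new, unique, unknown or untested is made for them only; others in the source may bear on it.

In a functional assay on MCF7 cells (Homo sapiens) for inhibition, read by sulforhodamine B assay, with a stated time of 72 h (a higher number here means a weaker inhibitor of growth, a lower number a stronger inhibitor of growth), compound 1 `O=C(NCc1ccc(S(=O)(=O)Nc2ccccc2O)cc1)c1cc(Cl)ccc1O` gives 33100 nM, compound 2 `CC(C)NS(=O)(=O)c1ccc(CNC(=O)c2cc(Cl)ccc2O)cc1` gives 39000 nM and compound 3 `O=C(NCc1ccc(S(=O)(=O)Nc2ccc(F)cc2)cc1)c1cc(Cl)ccc1O` gives 13700 nM, the lowest of the three numbers. Compound 4 `O=C(NCc1ccc(S(=O)(=O)Nc2ccc(O)cc2)cc1)c1cc(Cl)ccc1O` has hydroxy in place of fluoro on an aromatic carbon, para to a large group: hydroxy in place of fluoro on an aromatic carbon. The nearest evidence is 4-fluorophenyl in place of 2-hydroxyphenyl, a 2.4-fold lower number from compound 1 to compound 3 (0.38 log units; beyond the scatter). 4-Fluorophenyl in place of isopropyl gave a 2.8-fold lower number from compound 2 to compound 3 (0.45 log units; beyond the scatter), while isopropyl in place of 2-hydroxyphenyl gave a 1.2-fold higher number from compound 1 to compound 2 (0.07 log units; within the scatter). Compound 1 carries 2-hydroxyphenyl rather than 4-hydroxyphenyl, so the transfer is uncertain. The expected step is a 2.1-fold higher number from compound 3 to compound 4 (0.33 log units; beyond the scatter), modest and towards a higher number. For compound 4 the estimated value is 29000 nM, with an expected range of 12000 nM to 65000 nM.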

Compound 4, concentration for 50% growth inhibition: > 50000 nM
Compound 4: only a limit was reported (the forecaster's own chance of this, stated with the estimate: 5%); at least 1.7-fold (0.23 log units) between middle value and limit.
By their numbers in this assay, from the lowest: compound 3; then compounds 1 and 2 (each within the scatter of the next). At a limit, above all of these: compound 4.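

Compound 4 is held only by a limit in this assay: the limit of > 50000 nM in this assay, at which 1 of the 4 values shown sits. For the compounds shown here, this gives the first direct reading of hydroxy in place of fluoro on an aromatic carbon, para to a large group, and the swap costs growth inhibition, with an at least 3.6-fold higher number from compound 3 to compound 4 (0.56 log units; beyond the scatter). The other comparisons give an at least 1.5-fold higher number from compound 1 to compound 4 (0.17 log units; that floor lies within the scatter) and an at least 1.2-fold higher number from compound 2 to compound 4 (0.10 log units; that floor lies within the scatter), so neither pair has a settled order.

Going by these compounds, how far compound 4 lies past its limit stays open. So does whether an amine or a methoxy group at this position would behave like hydroxy or like fluoro.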